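From 3-methylthiophen-2-yl to 5-chloro-1H-indol-3-yl: working notes

The source may hold more compounds than are shown below. What is called first, only, known or untested is meant among the compounds shown, and "the series" means these compounds.

In a functional assay on DU-145 cells (Homo sapiens) for inhibition, read by trypan blue exclusion, with a stated time of 96 h (on this read-out lower numbers stand for stronger inhibition of growth and higher numbers for weaker inhibition of growth), compound 3 `Cc1ccc(CS/C(=C/c2sccc2C)C(=O)c2ccc(Cl)cc2)cc1` sits at 10000 nM as the middle of three numbers, with compound 1 `Cc1ccc(CS/C(=C/c2c(O)cc(O)cc2O)C(=O)c2ccc(Cl)cc2)cc1` at 50000 nM on the higher side and compound 2 `Cc1ccc(CS/C(=C/c2c[nH]c3ccc(Br)cc23)C(=O)c2ccc(Cl)cc2)cc1` at 1000 nM on the lower side.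

Compound 4 `Cc1ccc(CS/C(=C/c2c[nH]c3ccc(Cl)cc23)C(=O)c2ccc(Cl)cc2)cc1` carries 5-chloro-1H-indol-3-yl in place of 3-methylthiophen-2-yl on a double-bonded chain carbon bound to a double-bonded chain carbon. Counted, the exchange is 5-chloro-1H-indol-3-yl in place of 3-methylthiophen-2-yl on a double-bonded chain carbon bound to a double-bonded chain carbon and it leaves the rest of the structure unchanged.

The closest evidence comes from the 5-bromo-1H-indol-3-yl of compound 2. The exchange at this same place gives a 10-fold higher number from compound 2 to compound 3 (1.00 log units; beyond the scatter) and counts as modest but beyond the scatter. The two steps away from 2,4,6-trihydroxyphenyl agree in order: a 50-fold lower number from compound 1 to compound 2 (1.70 log units; beyond the scatter) is large and a 5.0-fold lower number from compound 1 to compound 3 (0.70 log units; beyond the scatter) is modest. Among the measured compounds shown here, no measured pair compares chloro with bromo on the indole, so that part of the change remains untested.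

A modest step toward a lower number is therefore expected in this assay, of about the size seen between the two measured groups. The expected step is a 10-fold lower number from compound 3 to compound 4 (1.00 log units; beyond the scatter) in this estimate. For compound 4 the estimate is 1000 nM (expected range 300 nM to 3500 nM).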

Compound 4, concentration for 50% growth inhibition: 1000 nM
Beside the measured number, compound 4's estimate shows no gap at the digits printed, and the stated range covers the measured number.
By their numbers in this assay, from the lowest: compounds 2 and 4 (each within the scatter of the next); then compound 3; then compound 1.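

In this assay, the exchange of bromo for chloro on the indole now has a reading (no change at the digits printed from compound 2 to compound 4 (within the scatter)), so 5-bromo-1H-indol-3-yl and 5-chloro-1H-indol-3-yl cannot be told apart at this place on a double-bonded chain carbon. The lower numbers therefore no longer rest on a single indole: compound 4 repeats the distance from the other two groups (a 10-fold lower number from compound 3 to compound 4 (1.00 log units; beyond the scatter); a 50-fold lower number from compound 1 to compound 4 (1.70 log units; beyond the scatter)), and the order of the groups holds for both halogens tested. Nothing measured here accounts for that order, which stands as a ranking of the four compounds only.

The compounds shown leave open how the number moves when the chloro or bromo on the indole gives way to a methoxy group, a nitrile or an amine, or when the indole carries no such group at all. They also leave open whether the same order would hold with changes elsewhere, since the rest of the structure is shared by all four compounds, for instance with a carboxylic acid on the shared core.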